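Exposure in Mice for a Fourth Benzyl Variant

This account rests on a few compounds, and the source may have more. Where it says the series, first, only, none or still open, it means among the compounds named here.

Measured compounds:
compound 1 `O=c1nc(N2CCN(CC3CCCCC3)CC2)sc2c([N+](=O)[O-])cc(C(F)(F)F)cc12`: 5480 ng.h/mL
compound 2 `O=c1nc(N2CCC3(CCN(Cc4cc(F)cc(F)c4)CC3)CC2)sc2c([N+](=O)[O-])cc(C(F)(F)F)cc12`: 2600 ng.h/mL
compound 3 `O=c1nc(N2CCC3(CCN(Cc4ccc(F)cc4)C3)CC2)sc2c([N+](=O)[O-])cc(C(F)(F)F)cc12`: 6020 ng.h/mL

In an ADME assay on the whole organism (strain ICR) for pharmacokinetics, with Mus musculus as the target, read by HPLC, at a dose of 50 mg/kg by the oral route (a higher number here means more compound in the circulation at the dose given, a lower number less compound in the circulation), compound 2 stands lowest of the three numbers. Compound 1 gives 5480 ng.h/mL, and compound 3 gives 6020 ng.h/mL; both of these gaps to compound 2 lie beyond the usual scatter.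

Compound 4 `O=c1nc(N2CCC3(CCN(Cc4ccc(Br)cc4)CC3)CC2)sc2c([N+](=O)[O-])cc(C(F)(F)F)cc12` differs from compound 2 in one place: 4-bromophenyl in place of 3,5-difluorophenyl on a saturated chain carbon bound to an amine nitrogen in a ring. Among the compounds with values here, no pair of measured compounds shows this change, so nothing in the measured set tells how large its effect is. The step is therefore expected to be modest, and in the direction of the other two compounds: a 1.3-fold higher number from compound 2 to compound 4 (0.13 log units; within the scatter). Compound 4 is estimated to give 3500 ng.h/mL, with a range from 1300 ng.h/mL to 9000 ng.h/mL.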

Compound 4, area under the concentration-time curve: 24600 ng.h/mL
Beside the measured number, compound 4's estimate is 7.0-fold (0.85 log units) below it; the whole stated range lies below it.
By their numbers in this assay, from the lowest: compound 2; then compounds 1 and 3 (each within the scatter of the next); then compound 4.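

In this assay, the change from 3,5-difluorobenzyl to 4-bromobenzyl is a large one, a 9.5-fold higher number from compound 2 to compound 4 (0.98 log units; beyond the scatter). The earlier compounds shown here differ in more than one place and could not show that this position alone, on a saturated chain carbon bound to an amine nitrogen in a ring, can shift the number this far. No available evidence accounts for the size of the step.

Compound 4 leaves open whether gaining the bromine or losing the two fluorines matters more. On these data alone, whether 4-chlorobenzyl or 4-methoxybenzyl would behave like 4-bromobenzyl also remains open.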